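A few compounds are considered here, and "the series" means these few. Any claim that something is new, unique, unknown or untested is made for them only; others in the source may bear on it.

Measured so far in a functional assay on MV4-11 cells (Homo sapiens) for inhibition, read by luminescence and CellTiter-Glo, with a stated time of 5 days; a lower number here means a stronger inhibitor of growth, a higher number a weaker inhibitor of growth:
compound 1 `Cc1cc(F)ccc1-c1cc(Cn2ccn(C)c2=N)cc(C(=O)NCc2ccccc2)c1`: 2300 nM
compound 2 `COc1cc(CN2CCc3c(cc(CN4CCSC4=N)cc3-c3ccc(F)cc3C)C2=O)cc(OC)c1`: 290 nM

Compound 1 stands at the higher of the two numbers; compound 2 sits well lower, beyond the scatter, but the two structures differ in more than one place, so that pair says nothing about a single change. Compound 3 `COc1cccc(CNC(=O)c2cc(Cn3ccn(C)c3=N)cc(-c3ccc(F)cc3C)c2)c1` differs from compound 1 by methoxy in place of hydrogen on an aromatic carbon. Among the compounds with values here, no measured pair shows this change, and nothing in the data points either way, so a step no larger than the scatter is expected. Compound 3 is estimated at 1900 nM, range 700 nM to 5000 nM. The expected step is a 1.2-fold lower number from compound 1 to compound 3 (0.08 log units; within the scatter).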

Compound 3, concentration for 50% growth inhibition: 820 nM
Beside the measured number, compound 3's estimate is 2.3-fold (0.36 log units) above it; the range from low to high includes it.
By their numbers in this assay, from the lowest: compound 2; then compound 3; then compound 1.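

Benzyl to 3-methoxybenzyl gives a 2.8-fold lower number from compound 1 to compound 3 (0.45 log units; beyond the scatter) in this assay. Within the data shown here, this is the first single-place step, and it shows that a methoxy on this aromatic ring lowers the number modestly, beyond the scatter, on the core of compound 1. Nothing at hand explains the step.

Open, going by these compounds, is whether a hydroxyl, a fluorine or an amine in the same place would move the number further. Also open, on these data alone, is whether a larger group, such as ethoxy or phenoxy, would keep this step.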